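A few compounds are considered here, and "the series" means these few. Any claim that something is new, unique, unknown or untested is made for them only; others in the source may bear on it.

Measured in a functional assay on A549 cells (Homo sapiens) for inhibition, read by sulforhodamine B assay; a higher number here means a weaker inhibitor, a lower number a stronger inhibitor:
- compound 1 `COC(=O)CC/C(C)=C/Cc1c(OC)c(C)c2c(c1OCC#CCN1CCN(c3ccc(O)cc3)CC1)C(=O)OC2`: > 50000 nM
- compound 2 `CCCCNc1ccc(CC#CCOc2c(C/C=C(\C)CCC(=O)OC)c(OC)c(C)c3c2C(=O)OC3)cc1`: 6970 nM
- compound 3 `COC(=O)CC/C(C)=C/Cc1c(OC)c(C)c2c(c1OCC#CCN1CCC(c3ccccc3)c3ccccc31)C(=O)OC2`: 7680 nM

Compound 1 gives only a limit of the assay, > 50000 nM, and not a number. Compound 2 at 6970 nM and compound 3 at 7680 nM do give numbers, and these two lie within the usual scatter of each other.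

The next compound, compound 4 `COC(=O)CC/C(C)=C/Cc1c(OC)c(C)c2c(c1OCC#CCN1CCN(c3ccc(C)cc3)CC1)C(=O)OC2`, keeps the shared core and the piperazine-bearing chain of compound 1. Within the data shown here, the one change is methyl in place of hydroxy on an aromatic carbon, which turns the 4-hydroxyphenyl into 4-methylphenyl.

Among the measured compounds shown here, no measured pair shows this change directly, so any forecast is uncertain. Compound 2 with 6970 nM and compound 3 with 7680 nM both lack the hydroxy and still give numbers, which points towards a measurable value for compound 4. The estimated change is an at least 3.5-fold lower number from compound 1 to compound 4 (0.55 log units; beyond the scatter), expected in the direction of stronger inhibition. For compound 4 the expected value is 14000 nM, within an estimated range of 5000 nM to 45000 nM.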

Compound 4, half-maximal inhibitory concentration: > 50000 nM
Compound 4 was reported as a limit; the forecaster's own chance of this, stated with the estimate: 30%; middle value at least 3.5-fold (0.55 log units) from the limit.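

No step from compound 1 to compound 4 can be read, because this assay gives only a limit for each of them, not a number: the limit of > 50000 nM in this assay, at which 2 of the 4 values shown sit.

The compounds shown leave open whether methyl in place of hydroxy changes inhibition at all.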